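From 4-fluorophenyl to 3-fluorophenyl at an assay limit

The source may report more compounds than this note shows. Statements on the series, on what has been measured and on what is new or still open speak of the compounds shown alone.

Compound 1 `Cc1cc(NC(=O)Nc2ccc(F)c(F)c2)c2ccccc2n1` gives > 25000 nM as a limit
Compound 2 `Cc1cc(NC(=O)Nc2ccc(F)cc2)c2ccccc2n1` gives > 25000 nM as a limit

In an ADME assay on Raji cells (Homo sapiens) for cytotoxicity, with a stated time of 72 h (a lower number here means that less compound is needed, a higher number that more compound is needed for the effect), compound 2 stands at > 25000 nM which is a limit and not a number. Compound 3 `Cc1cc(NC(=O)Nc2cccc(F)c2)c2ccccc2n1` differs from it in one place, 3-fluorophenyl in place of 4-fluorophenyl on an amide-type nitrogen with 3-fluorophenyl in place of 4-fluorophenyl on an amide-type nitrogen. Only a step that the two limits leave unreadable from compound 1 to compound 2 bears on this change, and it offers no size to carry over because the limit of > 25000 nM in this assay, at which 2 of the 2 values shown sit, is all that was seen. The estimated move, a step that the limit leaves unreadable from compound 2 to compound 3 in this assay, is therefore expected to be none beyond the scatter. Expected for compound 3 is 30000 nM within an estimated range of 15000 nM to 60000 nM and quite possibly only a limit again.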

Compound 3, half-maximal effective concentration: > 25000 nM
Compound 3: only a limit was reported; the forecaster's own chance of this, stated with the estimate: 85%; the middle value lies beyond the limit too.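

Compound 1, compound 2 and compound 3 all give only a limit in this assay, so no step between them can be read: the limit of > 25000 nM in this assay, at which 3 of the 3 values shown sit.

The compounds shown leave open whether 3-fluorophenyl and 4-fluorophenyl differ at all in this effect.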